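Naphthyl Ether Replaces Halophenyl: Liver Cell Toxicity Outlook

This account rests on a few compounds, and the source may have more. Where it says the series, first, only, none or still open, it means among the compounds named here.

Compound 1 `O=C(Nc1ncc(Cc2ccc(Cl)cc2)s1)c1cccs1` gives > 50000 nM in an ADME assay on HepG2 2.2.15 cells (Homo sapiens) for cytotoxicity (on this read-out lower numbers stand for higher toxicity in this test and higher numbers for lower toxicity in this test), which is a limit of the assay rather than a number. Compound 2 `CC(C)(C)OC(=O)Nc1ncc(C(Oc2ccc(F)c(Cl)c2)c2ccc(Cl)cc2)s1` gives > 50000 nM in this assay, again a limit and not a number.

Both measured values therefore sit at the limit of > 50000 nM in this assay, at which 2 of the 2 values shown sit. Compound 2 stands at that limit, so nothing separates it from compound 1 on the numbers shown, and no measured step between two compounds is available to size the change that follows. Compound 3 `CC(C)(C)OC(=O)Nc1ncc(C(Oc2ccc3cc(Br)ccc3c2)c2ccc(Cl)cc2)s1` differs from compound 2 by 6-bromonaphthalen-2-yl in place of 3-chloro-4-fluorophenyl on an oxygen on a saturated carbon. Without any measured step to lean on, the expected step is an at least 1.2-fold lower number from compound 2 to compound 3 (0.09 log units; that floor lies within the scatter), most likely nothing beyond the scatter, with the remaining chance leaning toward lower numbers rather than higher ones. Compound 3 is estimated at 40000 nM, within a range from 8000 nM to 100000 nM, and a reading that is again only a limit is considered more likely than not.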

Compound 3, half-maximal cytotoxic concentration: > 50000 nM
Compound 3 gave a limit, no number; the forecaster's own chance of this, stated with the estimate: 60%; at least 1.2-fold (0.09 log units) between middle value and limit.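

Among the compounds shown here, compound 3, like compound 2, reads only as a limit in this assay, so no step can be sized from compound 2 to compound 3: the limit of > 50000 nM in this assay, at which 3 of the 3 values shown sit. The compounds shown leave open whether 6-bromonaphthalen-2-yl in place of 3-chloro-4-fluorophenyl changes the result in this assay at all.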